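This account rests on a few compounds, and the source may have more. Where it says the series, first, only, none or still open, it means among the compounds named here.

The three measured compounds share one core and a chain at its edge. Compound 1 `CCCCCCCCCCc1cc2cn(COCCO)c(O)nc-2n1` gives 80000 nM in a functional assay on HEL cells (Homo sapiens), read by microscopy; on this read-out higher numbers stand for lower toxicity in this test and lower numbers for higher toxicity in this test. Compound 3 `CCCCCCCCCCc1cc2cn(COCCO)c(=O)nc2o1` gives 400000 nM in this assay. Compound 2 `CCCCCCC#Cc1cc2cn(COCCO)c(=O)nc2o1` is reported in this assay only as a limit of the assay, > 200000 nM, the point described by the limit of > 200000 nM in this assay, at which 1 of the 3 values shown sits. So compound 2 stands at the upper edge of what this assay records, and its place relative to compound 1 and compound 3 cannot be fixed. Compound 4 `CCCCCC#Cc1cc2cn(COCCO)c(=O)nc2o1` is still unmeasured in this assay. It differs from compound 2 by hydrogen in place of methyl on a saturated chain carbon, five bonds along the chain from a triple-bonded carbon. Among the measured compounds shown here, no measured step runs between any two compounds here. The change is the loss of one methyl at the chain end, and the step that the limit leaves unreadable from compound 2 to compound 4 is expected to stay within the scatter, in no clear direction. Compound 4 is expected to give about 250000 nM in this assay, between 100000 nM and 600000 nM, quite possibly again only as a limit.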

Compound 4, minimum cytotoxic concentration: >= 100000 nM
Compound 4: only a limit was reported (the forecaster's own chance of this, stated with the estimate: 60%); the middle value does not contradict the limit.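

Compound 2 and compound 4 are both reported only as limits in this assay, so no step can be read between them. The compounds shown leave open whether hydrogen in place of methyl changes this read-out at all.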